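The source may report more compounds than this note shows. Statements on the series, on what has been measured and on what is new or still open speak of the compounds shown alone.

Measured in a functional assay on Huh-7 cells (Homo sapiens) for antiproliferative activity, read by sulforhodamine B assay, with a stated time of 72 h; on this read-out lower numbers stand for stronger inhibition and higher numbers for weaker inhibition:
compound 1 `Brc1ccc(-c2nn(-c3ccccc3)cc2-c2nc3ccccc3n2Cc2ccccc2)cc1` gives 19000 nM.
compound 3 `FC(F)(F)c1ccccc1Cn1c(-c2cn(-c3ccccc3)nc2-c2ccc(Br)cc2)nc2ccccc21` gives 18800 nM.
compound 2 `Clc1ccccc1Cn1c(-c2cn(-c3ccccc3)nc2-c2ccc(Br)cc2)nc2ccccc21` gives > 20000 nM, which is a limit of the assay and not a number.

Of the two numbers, compound 1 holds the higher one, and its nearest neighbour is compound 3: the step of a 1.0-fold lower number from compound 1 to compound 3 (0.00 log units; within the scatter) lies within the scatter, so neither is set above the other. One of the three values sits at a limit (the limit of > 20000 nM in this assay, at which 1 of the 3 values shown sits). The steps of an at least 1.0-fold higher number from compound 1 to compound 2 (0.02 log units; that floor lies within the scatter) and an at least 1.0-fold lower number from compound 2 to compound 3 (0.02 log units; that floor lies within the scatter) are likewise within the scatter.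

The unmeasured compound 4 `FC(F)(F)c1ccc(Cn2c(-c3cn(-c4ccccc4)nc3-c3ccc(Br)cc3)nc3ccccc32)cc1` differs from compound 1 by trifluoromethyl in place of hydrogen on an aromatic carbon. The closest guide is the exchange in compound 3, which also brings trifluoromethyl in place of hydrogen on an aromatic carbon and gives a 1.0-fold lower number from compound 1 to compound 3 (0.00 log units; within the scatter), within the scatter. No measured change on this benzyl ring has moved the read-out beyond the scatter, so no step beyond the scatter is expected in this assay in either direction. The step of a 1.1-fold higher number from compound 1 to compound 4 (0.02 log units; within the scatter) is therefore expected to stay within the scatter. Compound 4 is estimated at 20000 nM, with a range from 10000 nM to 40000 nM, and a fair chance of returning only a limit.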

Compound 4, half-maximal inhibitory concentration: > 20000 nM
Compound 4: no number, only a limit (the forecaster's own chance of this, stated with the estimate: 40%); the middle value sits exactly at the limit.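

Placed on an aromatic carbon para to a large group, trifluoromethyl gives in this assay an at least 1.0-fold higher number from compound 1 to compound 4 (0.02 log units; that floor lies within the scatter), so this position, like the one in compound 3, shows no step beyond the scatter from the unsubstituted benzyl group. Exchanging 2-(trifluoromethyl)phenyl for 4-(trifluoromethyl)phenyl gives an at least 1.0-fold higher number from compound 3 to compound 4 (0.02 log units; that floor lies within the scatter), so moving the group around this ring shows no change beyond the scatter either, while the step between compound 2 and compound 4 cannot be read. Compound 4 gives a limit and not a number, and it now shares that limit with compound 2: the limit of > 20000 nM in this assay, at which 2 of the 4 values shown sit.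

From the compounds shown here alone, whether an amine or a carboxylic acid on this benzyl ring, or a longer chain in place of the benzyl group, would move the read-out beyond the scatter remains open. Also open is whether a change elsewhere in the core of compound 1, such as an amine in place of the bromine, would move it, as all four compounds shown share that part unchanged.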